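The compounds below may be only part of what the source reports. "The series", "measured", "known", "first", "only" and "open" are said of these compounds alone.

Working notes on the amide series. In a functional assay on HeLa cells (Homo sapiens) for antiproliferative activity, read by CCK-8 assay, with a stated time of 72 h (a lower number here means a stronger inhibitor of growth, a higher number a weaker inhibitor of growth), compound 3 (`CCC1C(=O)N(C)c2cnc(-n3ccc4cc(C(=O)NC(C)C)ccc43)nc2N1c1ccn(C)n1`) gives 4350 nM as its reading. This lies within the scatter of compound 1 (`CCC1C(=O)N(C)c2cnc(Nc3ccc(S(=O)(=O)NC)cc3)nc2N1c1ccn(C)n1`) at 2200 nM in the same test. Compound 2 (`CC[C@@H]1C(=O)N(C)c2cnc(-n3ccc4cc(C(N)=O)ccc43)nc2N1C1CCCC1`) reads 674 nM and so has a lower number than compound 3, a gap beyond the scatter.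

Next in line is compound 4 (`CCC1C(=O)N(C)c2cnc(-n3ccc4cc(C(=O)NC)ccc43)nc2N1c1ccn(C)n1`), which carries methyl in place of isopropyl on an amide-type nitrogen and is otherwise the same as compound 3. The same difference reads isopropylcarbamoyl to methylcarbamoyl.

Among the measured compounds shown here, no two measured compounds differ in one place only, so the data hold no direct measure of this change. The only hint of direction is compound 2 at 674 nM as its reading, which has neither isopropyl nor methyl on its amide nitrogen. It also differs from compound 3 elsewhere, so the hint is weak.

A small move toward a lower number is expected, not clearly beyond the scatter, with the estimated change being a 1.5-fold lower number from compound 3 to compound 4 (0.16 log units; within the scatter) in size. For compound 4 the estimated value is 3000 nM with an expected range of 1200 nM to 7000 nM in this assay when measured.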

Compound 4, concentration for 50% growth inhibition: 6330 nM
Estimate against measurement, compound 4: 2.1-fold (0.32 log units) below, within the range that was stated.
By their numbers in this assay, from the lowest: compound 2; then compounds 1, 3 and 4 (each within the scatter of the next, the first and the last beyond it).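

In this assay, among the compounds shown here, replacing isopropyl with methyl on the amide-type nitrogen gives a 1.5-fold higher number from compound 3 to compound 4 (0.16 log units; within the scatter), the first direct reading of any single change, and it leaves the two compounds indistinguishable in this test. For this one pair, then, going from three carbons to one on this nitrogen has no effect that can be separated from the scatter, and the reading gives no basis for preferring either group. No measured data on mechanism or on any property of these compounds bear on this result, so it stands as a bare observation on growth inhibition.

Open, from the compounds shown here alone, is whether a longer chain such as n-butyl, a chain ending in an amine, or a carboxylic acid in place of the whole methylcarbamoyl group would move the reading beyond the scatter, since isopropyl and methyl span only a narrow range of groups at this place. Also open, going by these compounds, is whether the same step would stay within the scatter with a different group elsewhere on the shared core, as this single pair covers only one such background.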